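Toward compound 4 in a cytotoxicity series on CNE-2 cells

The compounds below may be only part of what the source reports. "The series", "measured", "known", "first", "only" and "open" are said of these compounds alone.

Measured so far in a functional assay on CNE-2 cells (Homo sapiens) for cytotoxicity, read by sulforhodamine B assay, with a stated time of 48 h; a higher number here means a weaker inhibitor, a lower number a stronger inhibitor:
compound 1, `Nc1ccc(C(=O)/C=C/c2ccc(O)c(F)c2)cc1-c1ccc(F)cc1`, gives 18100 nM
compound 2, `O=C(/C=C/c1ccc(Cl)cc1)c1cccc(-c2cccc(F)c2)c1`, gives 9060 nM
compound 3, `COc1ccc(/C=C/C(=O)c2ccc(N)c(-c3ccc(OC)c(OC)c3)c2)c(OC)c1`, gives 8340 nM

Among these three numbers, compound 1 has the highest one. Its nearest neighbour is compound 2, whose value lies within the usual scatter of compound 1, so the two cannot be ordered. Compound 3 stands furthest from compound 1, and that gap lies beyond the scatter, so compound 3 is the stronger inhibitor of the pair in this assay.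

The next compound, compound 4, `COc1ccc(/C=C/C(=O)c2ccc(N)c(-c3ccc(F)cc3)c2)cc1`, has not yet been measured in this assay. It differs from compound 1 in one place: 4-methoxyphenyl in place of 3-fluoro-4-hydroxyphenyl on a double-bonded chain carbon bound to a double-bonded chain carbon. Going by the values given here, no step between two measured compounds isolates this change, so the size of its effect is open. On the numbers shown, compound 3, which also carries 4-methoxyphenyl on that chain carbon, gives 8340 nM, and this leads to an expectation of a modest move toward a stronger inhibitor, estimated as a 1.8-fold lower number from compound 1 to compound 4 (0.26 log units; within the scatter). Compound 4 is therefore expected to give about 10000 nM, in a range from 4000 nM to 30000 nM.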

Compound 4, half-maximal inhibitory concentration: 1600 nM
The estimate for compound 4 lay 6.3-fold (0.80 log units) above the measured number, and the stated range ends above it.
By their numbers in this assay, from the lowest: compound 4; then compounds 3, 2 and 1 (each within the scatter of the next, the first and the last beyond it).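

In this assay, 4-methoxyphenyl in place of 3-fluoro-4-hydroxyphenyl on a double-bonded chain carbon bound to a double-bonded chain carbon gives an 11-fold lower number from compound 1 to compound 4 (1.05 log units; beyond the scatter), a large step and the first in this set to isolate a single change. Going by these compounds alone, it shows that the group at this position can strongly affect the read-out on the core of compound 1, which the earlier compounds, with no one-place step among them, could not show. No measurement shown here explains the size of this step.

The exchange alters the fluorine, the hydrogen-bond donor and the methoxy carbon together, so the compounds shown do not assign the step to any one of them. Going by these compounds, whether 3-fluoro-4-methoxyphenyl or unsubstituted phenyl on that chain carbon would retain the stronger inhibition of compound 4 remains open.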